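A few compounds are considered here, and "the series" means these few. Any claim that something is new, unique, unknown or untested is made for them only; others in the source may bear on it.

Compound 1 `O=C(/C=C\Nc1cnc2ccccc2c1)c1c(-c2ccccc2)nc2ccccn12`: 2440 nM
Compound 2 `O=C(/C=C\Nc1ccc2[nH]ccc2c1)c1c(-c2ccc(Cl)cc2)nc2ccccn12`: 1290 nM

Both compounds were tested in a functional assay on DU-145 cells (Homo sapiens) for cytotoxicity, read by MTT assay, with a stated time of 48 h; a higher number here means a weaker inhibitor, a lower number a stronger inhibitor. Compound 2 gives 1290 nM, and compound 1 gives 2440 nM. These two numbers lie within the usual scatter of each other, so compound 2 does not stand apart from compound 1.

Compound 3 `O=C(/C=C\Nc1cnc2ccccc2c1)c1c(-c2ccc(Cl)cc2)nc2ccccn12` has not yet been measured. It carries quinolin-3-yl in place of 1H-indol-5-yl on an amine nitrogen. Within the data shown here, no measured pair of compounds shows this change alone, so its effect cannot be read directly from the data. With compound 1 at 2440 nM and compound 2 at 1290 nM, the expectation in this assay is no change beyond the scatter, and no firm direction. The expected step of a 1.2-fold higher number from compound 2 to compound 3 (0.09 log units; within the scatter) is small. For compound 3 the estimated value is 1600 nM, with an expected range from 650 nM to 3900 nM.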

Compound 3, half-maximal inhibitory concentration: 4170 nM
For compound 3 the middle estimate is 2.6-fold (0.42 log units) below the measured one; measured number outside the range, above it.
By their numbers in this assay, from the lowest: compounds 2, 1 and 3 (each within the scatter of the next, the first and the last beyond it).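

In this assay, among these compounds, the group on the amine nitrogen is the first change here to show a step beyond the scatter: quinolin-3-yl in place of 1H-indol-5-yl gives a 3.2-fold higher number from compound 2 to compound 3 (0.51 log units; beyond the scatter), a modest but readable loss of strength. By contrast, chloro in place of hydrogen on an aromatic carbon gives a 1.7-fold higher number from compound 1 to compound 3 (0.23 log units; within the scatter), which lies within the scatter, so these compounds show no clear effect of that change. Nothing available explains the step at the amine nitrogen.

As far as these compounds go, it remains open whether the step would hold with hydrogen rather than chloro on the aromatic carbon. From the compounds shown here alone, it is also open how a plain phenyl or a benzimidazolyl group on the amine nitrogen would compare with 1H-indol-5-yl and quinolin-3-yl.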